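A few compounds are considered here, and "the series" means these few. Any claim that something is new, unique, unknown or untested is made for them only; others in the source may bear on it.

Measured in a functional assay on MCF7 cells (Homo sapiens) for inhibition, read by MTT assay, with a stated time of 3 days; a higher number here means a weaker inhibitor, a lower number a stronger inhibitor:
- compound 1 `C=CCOc1cc(/C=C\c2cc(OC)c(OC)c(OC)c2)ccc1OC` gives 12000 nM
- compound 2 `COCOc1ccccc1/C=C/CCCOc1cc(/C=C\c2cc(OC)c(OC)c(OC)c2)ccc1OC` gives 4400 nM
- compound 3 `COCOc1ccc(/C=C/CCCOc2cc(/C=C\c3cc(OC)c(OC)c(OC)c3)ccc2OC)cc1` gives 42000 nM

Compound 3 has the highest number of the three. Compound 4 `COc1ccc(/C=C\c2cc(OC)c(OC)c(OC)c2)cc1OCCC/C=C/c1ccc(Cl)cc1` carries chloro in place of methoxymethoxy on an aromatic carbon, para to a large group: chloro in place of methoxymethoxy on an aromatic carbon. Within the data shown here, no measured step makes this exchange. Among the measured compounds shown here, the only step bearing on it is a 9.5-fold higher number from compound 2 to compound 3 (0.98 log units; beyond the scatter), a modest change within the same phenyl group. A step no larger than that is therefore expected in this assay, towards a lower number, since compound 3 stands at the top of the series. The expected step is a 2.1-fold lower number from compound 3 to compound 4 (0.32 log units; beyond the scatter). For compound 4 the estimate is 20000 nM, with an expected range of 6000 nM to 60000 nM.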

Compound 4, half-maximal inhibitory concentration: 40000 nM
Beside the measured number, compound 4's estimate is 2.0-fold (0.30 log units) below it, and the stated range covers the measured number.
By their numbers in this assay, from the lowest: compound 2; then compound 1; then compounds 4 and 3 (each within the scatter of the next).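

In this assay, the step of a 1.1-fold lower number from compound 3 to compound 4 (0.02 log units; within the scatter) leaves chloro and methoxymethoxy indistinguishable on this aromatic carbon, para to a large group, despite the loss of both hydrogen-bond acceptors. The step of a 9.1-fold higher number from compound 2 to compound 4 (0.96 log units; beyond the scatter) shows that 4-chlorophenyl, like 4-(methoxymethoxy)phenyl, stands well above 2-(methoxymethoxy)phenyl. The step of a 3.3-fold higher number from compound 1 to compound 4 (0.52 log units; beyond the scatter) shows that 4-(4-chlorophenyl)but-3-en-1-yl also gives a higher number than vinyl on this chain.

No evidence on the cause of these steps is available. Open, on these data alone, is whether 2-chlorophenyl would match 2-(methoxymethoxy)phenyl, and whether an amine or a carboxylic acid in place of chloro would shift the number.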